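A few compounds are considered here, and "the series" means these few. Any claim that something is new, unique, unknown or untested is made for them only; others in the source may bear on it.

Measured so far in an assay on CHO cells for inhibition of sodium-dependent dopamine transporter (Homo sapiens), read by scintillation counting, with a stated time of 10 min, tested at 10 uM; a lower number here means less inhibition, a higher number more inhibition at the concentration tested (going by the name of the read-out):
Compound 1, `COc1ccc(C(O)CCN2CC=C(Cc3ccccc3)CC2)cc1OC`, gives 61%.
Compound 2, `OC(CCN1CCC(O)(Cc2ccccc2)CC1)c1csc2ccccc12`, gives 64%.
Compound 3, `O=[N+]([O-])c1ccc(C(O)CCN2CC=C(Cc3ccccc3)CC2)cc1`, gives 55%.

Among the compounds with values here, of these three numbers, the one for compound 3 is the lowest, yet its gaps to compound 1 and to compound 2 both lie within the usual scatter of this assay, so the three compounds cannot be told apart on these data.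

Compound 4, `OC(CCN1CC=C(Cc2ccccc2)CC1)c1ccc(Cl)cc1`, differs from compound 3 in one place: chloro in place of nitro on an aromatic carbon. Within the data shown here, no step between measured compounds shows what this change does, so the expectation rests only on the near-equal numbers of compounds 1, 2 and 3. The step of a number 5 percentage points higher from compound 3 to compound 4 (within the scatter) is expected to be small, in no clear direction, and not beyond the scatter. Compound 4 is therefore estimated to give 60%, with a range from 45% to 75%.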

Compound 4, a percentage reported as inhibition, at one concentration (the size of the read-out at that concentration, not a potency): 61%
The estimate for compound 4 lay 1 percentage points below the measured number, and the stated range covers the measured number.
By their numbers in this assay, from the lowest: compounds 3, 1, 4 and 2 (each within the scatter of the next).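

In this assay, within the data shown here, chloro in place of nitro on this aromatic carbon, para to a large group, gives a number 6 percentage points higher from compound 3 to compound 4 (within the scatter) and so offers the first direct comparison at this position. On this read-out, the two groups cannot be told apart, so the swap shows no effect beyond the scatter. No measurement shown offers an explanation for this result.

Open, going by these compounds, is whether an amine or a carboxylic acid at this place would also fall within the scatter of these two compounds. This single pair also cannot show whether the same swap would behave alike on a different core, or whether a difference in potency lies hidden at the one concentration tested.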